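Furan series: hydroxylated amino sugar variant of compound 2

This account rests on a few compounds, and the source may have more. Where it says the series, first, only, none or still open, it means among the compounds named here.

Compound 2 `C[C@@H]1O[C@@H](OCC#Cc2c(-c3ccccc3)oc3ccccc23)CC[C@@H]1N` stands lowest of the three numbers measured in an assay on isolated protein for inhibition of DNA topoisomerase 1 (Homo sapiens), with a stated time of 30 min, tested at 100 uM; a lower number here means less inhibition, a higher number more inhibition at the concentration tested (going by the name of the read-out); in that assay compound 2 gives 20.2%. Nearest is compound 3 `C[C@@H]1O[C@@H](OCC#Cc2c(-c3ccccc3)sc3ccccc23)C[C@H](N)[C@H]1O`, which in this assay gives 32.2%, a gap beyond the scatter; furthest is compound 1 `Cc1ccc(S(=O)(=O)n2c(-c3ccccc3)c(C#CCO[C@H]3CC[C@H](N)[C@H](C)O3)c3ccccc32)cc1`, which in this assay gives 43.2%. Compound 3 differs from compound 2 in both the core and the sugar, so its value does not separate the two changes. Compound 4 `C[C@@H]1O[C@@H](OCC#Cc2c(-c3ccccc3)oc3ccccc23)C[C@H](N)[C@H]1O` keeps the core of compound 2 and carries the sugar of compound 3: a group of 9 heavy atoms (6 carbon, 1 nitrogen, 2 oxygen; one six-membered non-aromatic ring with 1 hetero atom) in place of a group of 8 heavy atoms (6 carbon, 1 nitrogen, 1 oxygen; one six-membered non-aromatic ring with 1 hetero atom), on an oxygen on a saturated carbon. Among the measured compounds shown here, no measured pair isolates this change. Because compound 3 gives 32.2%, a small rise is expected, with the step of a number 5.8 percentage points higher from compound 2 to compound 4 (within the scatter) possibly not exceeding the scatter. Compound 4 is estimated at 26%, range 12% to 40%.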

Compound 4, a percentage reported as inhibition, at one concentration (the size of the read-out at that concentration, not a potency): 25.5%
The estimate for compound 4 lay 0.5 percentage points above the measured number, and the stated range covers the measured number.
By their numbers in this assay, from the lowest: compounds 2, 4 and 3 (each within the scatter of the next, the first and the last beyond it); then compound 1.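

Working from the core of compound 2, the sugar of compound 3 on the oxygen gives in this assay a number 5.3 percentage points higher from compound 2 to compound 4 (within the scatter), the first step in the series that isolates this sugar change. On this core, the extra oxygen on the sugar therefore produces no shift that can be told from the scatter. No measurement here bears on why the step is this size.

From the compounds shown here alone, whether the same sugar change stays as small on the core of compound 1 remains open. So does whether a dimethylamino group in place of the sugar amine would move the number beyond the scatter.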